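The compounds below may be only part of what the source reports. "The series", "measured", "known", "first", "only" and "open" are said of these compounds alone.

In an ADME assay on TZM cells (Homo sapiens) for cytotoxicity, read by XTT assay, with a stated time of 4 days (on this read-out higher numbers stand for lower toxicity in this test and lower numbers for higher toxicity in this test), compound 3 `Cc1cc(/C=C/C#N)cc(C)c1Oc1cc(Nc2ccc(C#N)cc2)c(N)cc1[N+](=O)[O-]` gives > 24400 nM, which is a limit and not a number. Compound 2 `Cc1cc(/C=C/C#N)cc(C)c1Oc1cc(Nc2ccc(C#N)cc2)c(N)cc1C(N)=O` likewise gives only a limit, > 23600 nM. Compound 1 `Cc1cc(CO)cc(C)c1Oc1cc(Nc2ccc(C#N)cc2)c(N)cc1CO` alone gives a number, 15900 nM. Compound 4 `Cc1cc(/C=C/C#N)cc(C)c1Oc1cc(Nc2ccc(C#N)cc2)c(N)cc1S(N)(=O)=O` carries sulfamoyl in place of nitro on an aromatic carbon. Within the data shown here, the one measured step that bears on this change, a step that the two limits leave unreadable from compound 2 to compound 3, also exchanges the group at this place, with nitro in place of carbamoyl, and it has no readable size. No step beyond the scatter is therefore expected in this assay, and another limit is likely. The estimated step is an at least 1.1-fold lower number from compound 3 to compound 4 (0.04 log units; that floor lies within the scatter). For compound 4 the expected value is 22000 nM, with an estimated range of 10000 nM to 45000 nM.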

Compound 4, half-maximal cytotoxic concentration: > 21800 nM
Compound 4 was reported as a limit (the forecaster's own chance of this, stated with the estimate: 75%); the middle value is on the limit's open side.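

In this assay compound 4 gives > 21800 nM, which is a limit and not a number. Its steps from compound 2 and compound 3, both also limits, cannot be read. The compounds shown leave open whether sulfamoyl, nitro and carbamoyl at this place differ at all in this assay.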